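Swapping a Tetrazole for a Pyrazole in Compound 1

The source may hold more compounds than are shown below. What is called first, only, known or untested is meant among the compounds shown, and "the series" means these compounds.

Compound 1, `Cc1cc(C)c(NC(=O)N(Cc2cccc(-c3nnn(C)n3)c2)C2CCCCCC2)c(C)c1`: < 1 mg/kg
Compound 2, `O=C(Nc1c(F)cc(F)cc1F)N(Cc1ccc(-c2ccsc2)cc1)C1CCCCCC1`: > 1 mg/kg

Of the compounds shown here, two have been measured in a functional assay on a cell-free system (plasma) with sterol O-acyltransferase, Soat (Rattus norvegicus) as the target; on this read-out lower numbers stand for an effect already at smaller amounts and higher numbers for an effect only at larger amounts of compound. Compound 1 `Cc1cc(C)c(NC(=O)N(Cc2cccc(-c3nnn(C)n3)c2)C2CCCCCC2)c(C)c1` gives < 1 mg/kg, which is a limit of the assay rather than a number. Compound 2 `O=C(Nc1c(F)cc(F)cc1F)N(Cc1ccc(-c2ccsc2)cc1)C1CCCCCC1` gives > 1 mg/kg, again a limit. Compound 1 therefore stands at the limit of < 1 mg/kg in this assay, at which 1 of the 2 values shown sits. Compound 2 stands at the limit of > 1 mg/kg in this assay, at which 1 of the 2 values shown sits. Among the compounds with values here, the two differ in more than one place, so no single step connects them, and all that can be said is where each sits.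

Compound 3 `Cc1cc(C)c(NC(=O)N(Cc2cccc(-c3cc[nH]n3)c2)C2CCCCCC2)c(C)c1` has not yet been measured. It differs from compound 1 by 1H-pyrazol-3-yl in place of 2-methyl-2H-tetrazol-5-yl on an aromatic carbon. Within the data shown here, no measured pair shows a change of this kind, so the step is expected to stay within the usual scatter, in no clear direction. The estimated step is a step that the limit leaves unreadable from compound 1 to compound 3. Compound 3 is expected to give 0.8 mg/kg in this assay, between 0.25 mg/kg and 2.5 mg/kg, and may well again be reported only as a limit.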

Compound 3, dose for half-maximal effect: 0.097 mg/kg
Beside the measured number, compound 3's estimate is 8.2-fold (0.92 log units) above it; measured number below the stated range.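

In this assay, compound 1 gives < 1 mg/kg, which is a limit and not a number. The step from compound 1 to compound 3, 1H-pyrazol-3-yl in place of 2-methyl-2H-tetrazol-5-yl, therefore cannot be read. The compounds shown leave open how large that step is and in which direction it runs.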